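A few compounds are considered here, and "the series" means these few. Any claim that something is new, unique, unknown or untested is made for them only; others in the source may bear on it.

Measured so far in a functional assay on NPC-TW01 cells (Homo sapiens) for inhibition, read by MTT assay, with a stated time of 72 h; a higher number here means a weaker inhibitor of growth, a lower number a stronger inhibitor of growth:
compound 1 `COC(=O)c1nc(C)n(-c2ccc(OC)cc2)n1` gives 9920 nM;
compound 2 `COC(=O)c1nc(C2CC2)n(-c2ccc(F)cc2)n1` gives 95900 nM.

Compound 2 stands at the higher of these two numbers, the weaker growth inhibitor of the pair; compound 1 sits well below it, and that gap is beyond the usual scatter of repeated measurements. The two compounds differ in more than one place, so the gap cannot be tied to any single change. The step of interest goes from compound 2 to compound 3 `COC(=O)c1nc(-c2ccccc2)n(-c2ccc(F)cc2)n1`, which carries phenyl in place of cyclopropyl on an aromatic carbon. Among the compounds with values here, no pair of measured compounds shows this exchange, so its effect on growth inhibition is not known from the data at hand. The expectation for compound 3 is a move toward a lower number, of a size that may not pass beyond the scatter, as the step of a 2.4-fold lower number from compound 2 to compound 3 (0.38 log units; beyond the scatter). The estimate for compound 3 in this assay is 40000 nM, with a range from 8000 nM to 150000 nM.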

Compound 3, concentration for 50% growth inhibition: 15600 nM
Estimate against measurement, compound 3: 2.6-fold (0.41 log units) above; the measured number falls inside the stated range.
By their numbers in this assay, from the lowest: compounds 1 and 3 (each within the scatter of the next); then compound 2.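

In this assay, within the data shown here, the exchange of cyclopropyl for phenyl, on the aromatic carbon between two ring nitrogen atoms, gives a 6.1-fold lower number from compound 2 to compound 3 (0.79 log units; beyond the scatter) and is the first change in a single place that can be read in this set. The step lies beyond the scatter, so at this position the phenyl group, with 6 heavy atoms, goes with stronger growth inhibition than the cyclopropyl group, with 3 heavy atoms. No measurement at hand gives a reason for this shift.

Going by these compounds, this is one pair of compounds, so it remains open whether the same exchange would act alike with a different group on the ring nitrogen. Also open, on these data alone, is how a cyclohexyl group, a pyridyl ring or an amine would compare at this same carbon.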